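Extending a branched amide into an acylurea

The source may report more compounds than this note shows. Statements on the series, on what has been measured and on what is new or still open speak of the compounds shown alone.

Compound 1 `CCC[C@@H](C(N)=O)C(C)C` and compound 2 `CCCC(C(N)=O)C(C)C` share the same atoms and bonds. In a functional assay on the whole organism (strain Sprague-Dawley) with Rattus norvegicus as the target, in the maximal electroshock model (on this read-out higher numbers stand for an effect only at larger amounts of compound and lower numbers for an effect already at smaller amounts), compound 1 gives 47 mg/kg, and compound 2 gives 50 mg/kg. Among the compounds with values here, the only measured step, a 1.1-fold higher number from compound 1 to compound 2 (0.03 log units; within the scatter), is too small to separate the two, which fits with the fact that one of compounds 1 and 2 is drawn with a defined configuration and the other without, at the place where they differ: the difference lies only in how the stereocentre is drawn.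

Compound 3 `CCC[C@@H](C(=O)NC(N)=O)C(C)C` differs from compound 1 by carbamoyl in place of hydrogen on an amide-type nitrogen; read one bond further out, amino becomes ureido. Within the data shown here, no measured step touches this change, since the step between compound 1 and compound 2 concerns stereochemistry alone, so it offers no guide to direction or size. Compound 3 is therefore expected to sit near compound 1, with a step of a 1.2-fold lower number from compound 1 to compound 3 (0.07 log units; within the scatter) in this assay that lies within the scatter. For compound 3 the estimated value is 40 mg/kg, with a range from 18 mg/kg to 90 mg/kg.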

Compound 3, dose for half-maximal effect: 36 mg/kg
For compound 3 the middle estimate is 1.1-fold (0.05 log units) above the measured one; measured number inside the range.
By their numbers in this assay, from the lowest: compounds 3, 1 and 2 (each within the scatter of the next).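

In this assay, carbamoyl in place of hydrogen on an amide-type nitrogen gives a 1.3-fold lower number from compound 1 to compound 3 (0.12 log units; within the scatter), so compound 1 and compound 3 cannot be told apart. Within the data shown here, this is the first look at a change to the amide itself rather than to how the stereocentre is drawn, and it shows that the effect in this whole-animal test persists when amino becomes ureido, a change that adds 3 heavy atoms. No information given here accounts for this outcome.

As far as these compounds go, whether the same holds for a smaller or differently shaped group at this nitrogen, such as methyl or acetyl, remains open. Also open, from the compounds shown here alone, is whether extending the ureido with a terminal methyl or a longer chain would keep the effect at similar doses.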